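The source may hold more compounds than are shown below. What is called first, only, known or untested is meant among the compounds shown, and "the series" means these compounds.

Measured compounds

compound 1: `CC(C)C[C@@H](C(=O)N[C@H](C(=O)Nc1nccs1)C(C)(C)C)[C@H](C)N(O)C=O` — in an assay on isolated protein for inhibition of matrix metalloproteinase-9 (Homo sapiens) (on this read-out higher numbers stand for weaker inhibition and lower numbers for stronger inhibition), compound 1 gives 34 nM
compound 2: `CC(C)C[C@@H](C(=O)N[C@@H](CC(C)(C)C)C(=O)Nc1nccs1)[C@H](C)N(O)C=O` — in this assay compound 2 gives 98 nM

Within the data shown here, compound 2 gives the highest of the two numbers so far; its nearest neighbour is compound 1, and the only step measured, a 2.9-fold higher number from compound 1 to compound 2 (0.46 log units; beyond the scatter), separates them by exchanging neopentyl for tert-butyl on the saturated chain carbon bound to the amide-type nitrogen and the carbonyl carbon.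

Compound 3 is `CC(C)C[C@H](NC(=O)[C@H](CC(C)C)[C@H](C)N(O)C=O)C(=O)Nc1nccs1`, not yet measured. Relative to compound 2 the change is hydrogen in place of methyl on a saturated chain carbon bound to three saturated chain carbons, which at one bond further out reads neopentyl to isobutyl.

Among the measured compounds shown here, no measured step covers this change. For the measured compounds named here, the one measured step, a 2.9-fold higher number from compound 1 to compound 2 (0.46 log units; beyond the scatter), concerns a different place (the carbon bound to the amide-type nitrogen and the carbonyl carbon) and is only modest, so it offers indirect guidance at best. Going by the values given here, with no direct precedent, the step of a 1.0-fold higher number from compound 2 to compound 3 (0.01 log units; within the scatter) is expected to stay within the usual scatter, with the range widened to allow a modest movement either way. For compound 3 the expected value in this assay is therefore 100 nM, with a range from 40 nM to 250 nM.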

Compound 3, inhibition constant: 17 nM
Estimate against measurement, compound 3: 5.9-fold (0.77 log units) above; measured number below the stated range.
By their numbers in this assay, from the lowest: compounds 3 and 1 (each within the scatter of the next); then compound 2.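

In this assay the step of a 5.8-fold lower number from compound 2 to compound 3 (0.76 log units; beyond the scatter) shows that this position responds to a single methyl at the end of the side chain: hydrogen in place of methyl on the saturated chain carbon bound to three saturated chain carbons, read one bond further out as neopentyl to isobutyl, is a change beyond the scatter. The step of a 2.0-fold lower number from compound 1 to compound 3 (0.30 log units; within the scatter) stays within the scatter, so isobutyl and tert-butyl cannot be told apart here and, of the three groups shown, neopentyl alone stands apart with the highest number, which means the series gives no steady trend as the group changes. Nothing available on these compounds speaks to the origin of this difference.

The compounds shown carry only branched saturated groups at this carbon, so it remains open how a straight n-butyl chain, a longer chain, or a chain ending in an amine or a carboxylic acid would read in this assay against compound 3 and compound 1. Going by these compounds, whether the neopentyl to isobutyl difference carries over to a different group on the rest of the shared core also stays open.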